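Oxazole substituent exchange in the phenoxyphenyl ketone series

This account rests on a few compounds, and the source may have more. Where it says the series, first, only, none or still open, it means among the compounds named here.

Of the compounds shown here, two have a number so far. Compound 1 `CN(C)C(=O)c1cnc(C(=O)CCc2ccc(Oc3ccccc3)cc2)o1` gives 5.4 nM in an assay for inhibition of Fatty-acid amide hydrolase 1 (Rattus norvegicus) (on this read-out lower numbers stand for stronger inhibition and higher numbers for weaker inhibition), and stands with the lowest of the two numbers; compound 2 `CN(C)C(=O)c1cnc(C(=O)CCc2ccc(COc3ccccc3)cc2)o1` gives 6.7 nM in this assay, and the step of a 1.2-fold higher number from compound 1 to compound 2 (0.09 log units; within the scatter) is the only measured one, concerning the phenoxy part rather than the core substituent. Compound 3 `O=C(O)c1ccc(-c2cnc(C(=O)CCc3ccc(Oc4ccccc4)cc3)o2)nc1` differs from compound 1 by 5-carboxypyridin-2-yl in place of dimethylcarbamoyl on an aromatic carbon. Among the measured compounds shown here, no measured step touches this position of the core, so the single step from compound 1 to compound 2 offers no direct guide, and the expectation rests on compound 1 alone. The working assumption is that the core substituent is tolerated, with a modest shift either way, so compound 3 is expected at 6 nM in this assay, within 1.5 nM to 25 nM, a step of a 1.1-fold higher number from compound 1 to compound 3 (0.05 log units; within the scatter) that is expected to stay close to the scatter.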

Compound 3, inhibition constant: 33 nM
The estimate for compound 3 lay 5.5-fold (0.74 log units) below the measured number, and the stated range ends below it.
By their numbers in this assay, from the lowest: compounds 1 and 2 (each within the scatter of the next); then compound 3.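

At this aromatic carbon, next to the ring oxygen, the exchange in this assay gives a 6.1-fold higher number from compound 1 to compound 3 (0.79 log units; beyond the scatter), the first step measured at this position and one that lies beyond the scatter. The position thus responds to its substituent, although compound 3, with a six-membered aromatic ring and a carboxylic acid in the entering group, still reads 33 nM. No available measurement bears on the reason for this shift.

From the compounds shown here alone, the entering group differs from dimethylcarbamoyl in both its ring and its carboxylic acid, so the share of each in the step stays open. Going by these compounds, it also remains open whether a plain pyridin-2-yl, or a methyl ester in place of the carboxylic acid, would read closer to compound 1 or to compound 3.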